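The source may report more compounds than this note shows. Statements on the series, on what has been measured and on what is new or still open speak of the compounds shown alone.

Compound 1 `CN1C/C(=C\c2ccc(Cl)cc2)C(=O)/C(=C/c2cccc([N+](=O)[O-])c2)C1` gives 8210 nM in a functional assay on HepG2 cells (Homo sapiens) for cytotoxicity, read by MTT assay, with a stated time of 24 h; on this read-out higher numbers stand for weaker inhibition and lower numbers for stronger inhibition.
Compound 2 `CN1C/C(=C\c2ccc(Br)cc2)C(=O)/C(=C/c2cccc([N+](=O)[O-])c2)C1` gives 8800 nM.
Compound 3 `CN1C/C(=C\c2ccc(Cl)cc2)C(=O)/C(=C/c2ccc(C#N)cc2)C1` gives 5950 nM.

Compounds 1 and 2 differ in one place, (bromo in place of chloro on an aromatic carbon), and this gives a 1.1-fold higher number from compound 1 to compound 2 (0.03 log units; within the scatter). Compound 3 and compound 1 share a core whose difference is not broken down here. Compound 4 `CN1C/C(=C\c2ccc(Br)cc2)C(=O)/C(=C/c2ccc(C#N)cc2)C1` has not yet been measured; it differs from compound 3 by bromo in place of chloro on an aromatic carbon, the same change as that from compound 1 to compound 2, at the same place. Because the step of a 1.1-fold higher number from compound 1 to compound 2 (0.03 log units; within the scatter) stayed within the scatter, the step from compound 3 to compound 4 is expected to be of the same small size, estimated as a 1.1-fold higher number from compound 3 to compound 4 (0.04 log units; within the scatter). Compound 4 is therefore expected to give about 6500 nM, lying between 3500 nM and 12000 nM.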

Compound 4, half-maximal inhibitory concentration: 4840 nM
Beside the measured number, compound 4's estimate is 1.3-fold (0.13 log units) above it; the measured number falls inside the stated range.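

Bromo in place of chloro on the core of compound 3 gives a 1.2-fold lower number from compound 3 to compound 4 (0.09 log units; within the scatter) in this assay. Set beside the earlier step, the two results do not differ: the same change on two cores in this assay, a 1.1-fold higher number (0.03 log units; within the scatter) from compound 1 to compound 2 and a 1.2-fold lower number (0.09 log units; within the scatter) from compound 3 to compound 4, 1.3-fold (0.12 log units) apart, within the scatter of two such steps. This shows that in these two pairs the change stays small on both cores, but it gives no reliable direction or size for either step, and two cores cannot show that the same would hold on any other core in the series.

The compounds shown leave open whether a different group at this place, such as an amine, a carboxylic acid or a longer chain, would shift the number beyond the scatter. They also leave open how a methoxy group would behave there.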